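Ethylpiperazine in place of dimethylpiperazine on a shared core

The source may hold more compounds than are shown below. What is called first, only, known or untested is meant among the compounds shown, and "the series" means these compounds.

Compound 1 `CN(C[C@H]1Cc2c(cccc2N2CCNC(C)(C)C2)CN1)[C@H]1CCCc2cccnc21` gives 33.9 nM in a functional assay on CCRF-CEM cells for antagonist activity at C-X-C chemokine receptor type 4 (Homo sapiens), read by calcium flux, with stated times of 25 min and 90 s (a lower number here means a stronger inhibitor, a higher number a weaker inhibitor), the second highest of three numbers. Compound 3 `CCN(C[C@H]1Cc2c(cccc2N2CCNCC2)CN1)[C@H]1CCCc2cccnc21` gives 14.8 nM, and compound 2 `FC1(F)CCC(CN(C[C@H]2Cc3c(cccc3N3CCNCC3)CN2)[C@H]2CCCc3cccnc32)CC1` gives 498 nM. Among the compounds with values here, the one change measured in a single place, a 34-fold lower number from compound 2 to compound 3 (1.53 log units; beyond the scatter), concerns the substituent on the amine nitrogen, not the ring that is altered here. Compound 4 `CCN1CCN(c2cccc3c2C[C@H](CN(C)[C@H]2CCCc4cccnc42)NC3)CC1` differs from compound 1 by 4-ethylpiperazin-1-yl in place of 3,3-dimethylpiperazin-1-yl on an aromatic carbon. Within the data shown here, no measured step bears directly on this change, so the direction is open. Compound 1 and compound 3, which share neither the amine substituent nor the piperazine substitution, differ only modestly. Compound 4 is therefore expected to show a step of a 1.2-fold higher number from compound 1 to compound 4 (0.07 log units; within the scatter), lying near the scatter, with an estimate of 40 nM and a range from 12 nM to 130 nM.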

Compound 4, half-maximal inhibitory concentration: 13.8 nM
Beside the measured number, compound 4's estimate is 2.9-fold (0.46 log units) above it; the measured number falls inside the stated range.
By their numbers in this assay, from the lowest: compounds 4 and 3 (each within the scatter of the next); then compound 1; then compound 2.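

Within the data shown here, exchanging 3,3-dimethylpiperazin-1-yl for 4-ethylpiperazin-1-yl on this aromatic carbon gives a 2.5-fold lower number from compound 1 to compound 4 (0.39 log units; beyond the scatter) in this assay, the first measured step at this position. The entering group has no hydrogen-bond donor and the leaving group has one, yet the number falls rather than rises. No evidence here accounts for this step.

The compounds shown do not separate the effect of adding the ethyl group from that of removing the two methyl groups. On these data alone, how a longer chain such as propyl on that nitrogen, or a morpholine ring on this carbon, would read remains open.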